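Swapping a piperidine amide for a chlorobenzyl amide

The source may hold more compounds than are shown below. What is called first, only, known or untested is meant among the compounds shown, and "the series" means these compounds.

Of the compounds shown here, three built on one shared core have been measured in an assay on microsomes from liver for inhibition of 3-hydroxy-3-methylglutaryl-coenzyme A reductase (Rattus norvegicus); on this read-out higher numbers stand for weaker inhibition and lower numbers for stronger inhibition. Compound 1 `Cc1ccc(CNC(=O)c2nn(-c3ccc(F)cc3)c(OC[C@@H](O)C[C@@H](O)CC(=O)O)c2C(C)C)cc1` gives 15 nM, compound 2 `Cc1cccc(CNC(=O)c2nn(-c3ccc(F)cc3)c(OC[C@@H](O)C[C@@H](O)CC(=O)O)c2C(C)C)c1` gives 4.9 nM, and compound 3 `CC(C)c1c(C(=O)N2CCCCC2)nn(-c2ccc(F)cc2)c1OC[C@@H](O)C[C@@H](O)CC(=O)O` gives 47 nM. Compound 3 therefore carries the highest number of the three, which on this read-out means the weakest inhibition shown so far. Two measured steps lead to it from its amide relatives, each differing in only one place: a 3.1-fold higher number from compound 1 to compound 3 (0.50 log units; beyond the scatter) and a 9.6-fold higher number from compound 2 to compound 3 (0.98 log units; beyond the scatter). Compound 4 `CC(C)c1c(C(=O)NCc2ccc(Cl)cc2)nn(-c2ccc(F)cc2)c1OC[C@@H](O)C[C@@H](O)CC(=O)O` has not yet been measured. It differs from compound 3 by (4-chlorobenzyl)amino in place of piperidin-1-yl on a carbonyl carbon. This runs opposite to the two measured steps, in which replacing a benzyl-type amine with piperidin-1-yl raised the number, once modestly and once more strongly. The expected move in this assay is therefore towards a lower number, a 3.9-fold lower number from compound 3 to compound 4 (0.59 log units; beyond the scatter). Compound 4 is estimated at 12 nM, within a range from 4 nM to 35 nM.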

Compound 4, half-maximal inhibitory concentration: 6.7 nM
For compound 4 the middle estimate is 1.8-fold (0.25 log units) above the measured one; low and high end bracket the measured number.
By their numbers in this assay, from the lowest: compounds 2 and 4 (each within the scatter of the next); then compound 1; then compound 3.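

In this assay, going by these compounds alone, a third benzyl-type amine now gives a lower number than the piperidin-1-yl group on the same carbonyl carbon (a 7.0-fold lower number from compound 3 to compound 4 (0.85 log units; beyond the scatter)), so all three benzyl-type amides shown sit below compound 3, with no compound against this pattern. The group on the benzyl ring also counts: chloro in place of methyl at the same spot gives a 2.2-fold lower number from compound 1 to compound 4 (0.35 log units; beyond the scatter), while 4-chlorophenyl in place of 3-methylphenyl gives a 1.4-fold higher number from compound 2 to compound 4 (0.14 log units; within the scatter), so compound 2 and compound 4 cannot be told apart here. No supporting measurement explains these differences.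

From the compounds shown here alone, it stays open how a plain benzylamino group, with neither chloro nor methyl on its ring, would compare. A methyl(benzyl)amino group, which lacks the amide hydrogen, could show whether that hydrogen matters.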